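The source may report more compounds than this note shows. Statements on the series, on what has been measured and on what is new or still open speak of the compounds shown alone.

Measured compounds:
compound 1 `COc1cccc(COc2ccccc2C2=NOC(CCl)C2)c1` gives 66000 nM
compound 2 `COc1cccc(COc2ccccc2C2=NOC(CO)C2)c1` gives 115000 nM
compound 3 `COc1ccc(COc2ccc(Br)cc2-c2cc(CCl)on2)cc1` gives > 300000 nM

These values come from an assay with Cystic fibrosis transmembrane conductance regulator (Rattus norvegicus) as the target; on this read-out lower numbers stand for tighter binding and higher numbers for weaker binding. Compound 3 returns only a limit in this assay, not a number (the limit of > 300000 nM in this assay, at which 1 of the 3 values shown sits). Compound 4 `COc1ccc(COc2ccc(Br)cc2-c2cc(CO)on2)cc1` has not been measured in this assay. Between compound 1 and compound 2 the change is hydroxy in place of chloro on a saturated chain carbon bound to a saturated ring carbon, and in this assay it made a step of a 1.7-fold higher number from compound 1 to compound 2 (0.24 log units; within the scatter). Between compound 3 and compound 4 the change is hydroxy in place of chloro on a saturated chain carbon bound to an aromatic carbon, the same kind of change, though here the saturated chain carbon is bound to an aromatic carbon rather than to a saturated ring carbon. The difference between the two cores is not broken down here. Given that compound 3 already sits at a limit in this assay the limit of > 300000 nM in this assay, at which 1 of the 3 values shown sits, and that the earlier step of a 1.7-fold higher number from compound 1 to compound 2 (0.24 log units; within the scatter) lay within the scatter, compound 4 is expected to move by about a step that the limit leaves unreadable from compound 3 to compound 4 in this assay. Compound 4 is therefore estimated at 500000 nM, most likely again returned as a limit, with a range from 200000 nM to 1500000 nM.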

Compound 4, dissociation constant: 104000 nM
Compound 4: middle estimate off by 4.8-fold (0.68 log units), on the high side; measured number outside the range, below it.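

In this assay, hydroxy in place of chloro on a saturated chain carbon bound to an aromatic carbon gave an at least 2.8-fold lower number from compound 3 to compound 4 (0.46 log units; beyond the scatter). The same kind of change therefore did not carry over unchanged from one core to the other: the same change on two cores in this assay, a 1.7-fold higher number (0.24 log units; within the scatter) from compound 1 to compound 2 and an at least 2.8-fold lower number (0.46 log units; beyond the scatter) from compound 3 to compound 4, at least 5.0-fold (0.70 log units) apart, beyond the scatter of two such steps. As far as these compounds go, compound 3 stands at a limit of the assay, so the full size of the new step stays unknown, and these two pairs alone do not show which of the differences between the cores sets the two steps apart: the limit of > 300000 nM in this assay, at which 1 of the 4 values shown sits.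

From the compounds shown here alone, it remains open how an amine, a carboxylic acid or a longer chain in place of the chloromethyl or hydroxymethyl group would read on either core. Also open, going by these compounds, is how chloromethyl to hydroxymethyl would behave on a core that differs from the core of compound 1 in one place only, which could tie the gap to a single feature.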